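The source may hold more compounds than are shown below. What is called first, only, known or untested is meant among the compounds shown, and "the series" means these compounds.

Compound 2, with the structure `O=S(=O)(NCCCNCc1ccc(Cl)c(C(F)(F)F)c1)c1cc(C(F)(F)F)cc(C(F)(F)F)c1`, gives 3000 nM in a functional assay on HPAC cells (Homo sapiens) for inhibition, read by MTT assay, with a stated time of 72 h; on this read-out higher numbers stand for weaker inhibition of growth and lower numbers for stronger inhibition of growth. On the numbers in hand compound 2 stands highest of the two, its nearest neighbour being compound 1, with the structure `O=S(=O)(NCCCNCc1ccc(Cl)c(Cl)c1)c1cc(C(F)(F)F)cc(C(F)(F)F)c1`, which in this assay gives 2500 nM; the two lie within the scatter of each other. For the measured compounds named here, the only measured step, a 1.2-fold higher number from compound 1 to compound 2 (0.08 log units; within the scatter), describes a change within the scatter.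

Compound 3, with the structure `O=S(=O)(NCCCNCc1ccc(Br)cc1)c1cc(C(F)(F)F)cc(C(F)(F)F)c1`, differs from compound 2 by 4-bromophenyl in place of 4-chloro-3-(trifluoromethyl)phenyl on a saturated chain carbon bound to an amine nitrogen. Going by the values given here, this change removes the trifluoromethyl whose introduction was the substance of the step of a 1.2-fold higher number from compound 1 to compound 2 (0.08 log units; within the scatter), and at the same time exchanges the chloro for a bromo on the six-membered aromatic ring of carbon only; no measured step covers the halogen exchange. Among the compounds with values here, since the one step that bears on the change fell within the scatter, compound 3 is expected to show no step in this assay beyond the scatter, that is no change at the digits printed from compound 2 to compound 3 (within the scatter). Compound 3 is therefore estimated at 3000 nM, with a likely range from 1200 nM to 8000 nM.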

Compound 3, concentration for 50% growth inhibition: 2900 nM
Compound 3: the middle estimate sits 1.0-fold (0.01 log units) above what was measured, within the range that was stated.
By their numbers in this assay, from the lowest: compounds 1, 3 and 2 (each within the scatter of the next).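

The earlier pair differed only by one substituent on the aromatic ring, whereas here the whole 4-chloro-3-(trifluoromethyl)phenyl with its 11 heavy atoms gives way to 4-bromophenyl with 7 heavy atoms, and this assay records a 1.0-fold lower number from compound 2 to compound 3 (0.01 log units; within the scatter) for this change. Set against 3,4-dichlorophenyl, the same group gives a 1.2-fold higher number from compound 1 to compound 3 (0.06 log units; within the scatter) at this place, on a saturated chain carbon bound to an amine nitrogen. All three halogenated phenyl groups thus lie within the scatter of one another, so these compounds show no separable contribution from the trifluoromethyl, the chloro or the bromo to inhibition of growth. No measurement is available that would explain why these numbers stay together.

Going by these compounds, it remains open whether any group at this place would move the number beyond the scatter, for instance an unsubstituted phenyl, or a phenyl carrying a methoxy, an amine or a carboxylic acid. On these data alone, all three compounds also share the same core, so the effect of a longer chain in that core remains equally open.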